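The source may report more compounds than this note shows. Statements on the series, on what has been measured and on what is new or still open speak of the compounds shown alone.

Measured compounds in a functional assay on UACC-62 cells (Homo sapiens) for inhibition, read by sulforhodamine B assay, with a stated time of 48 h; on this read-out higher numbers stand for weaker inhibition of growth and lower numbers for stronger inhibition of growth:
compound 1, `Nc1cc(N)c2nc(-c3ccccc3)c(Oc3ccc(F)cc3)nc2c1`: 33100 nM
compound 2, `COc1cc(CNc2nc3cc(N)cc(N)c3nc2-c2ccccc2)cc(OC)c1OC`: 15500 nM
compound 3, `COc1ccc(CNc2nc3cc(N)cc(N)c3nc2-c2ccccc2)cc1OC`: 26300 nM

Compound 3 holds the second highest of the three numbers in this assay. Its nearest neighbour is compound 1 at 33100 nM, its furthest compound 2 at 15500 nM, and both gaps stay within the scatter, so no ordering among the three is established.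

Compound 4, `COc1ccc(CNc2nc3cc(N)cc(N)c3nc2-c2ccccc2)cc1`, differs from compound 3 by hydrogen in place of methoxy on an aromatic carbon. Going by the values given here, the only measured step of the same kind is a 1.7-fold higher number from compound 2 to compound 3 (0.23 log units; within the scatter), a methoxy removed from the same ring, which did not move the number beyond the scatter. On that basis compound 4 is expected to show a 1.1-fold higher number from compound 3 to compound 4 (0.06 log units; within the scatter), at most a slight drift upward. The estimate for compound 4 is 30000 nM, with a range of 12000 nM to 75000 nM.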

Compound 4, concentration for total growth inhibition: 29500 nM
Compound 4: middle estimate off by 1.0-fold (0.01 log units), on the high side, and the stated range covers the measured number.
By their numbers in this assay, from the lowest: compounds 2, 3, 4 and 1 (each within the scatter of the next, the first and the last beyond it).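

In this assay, the change from 3,4-dimethoxyphenyl to 4-methoxyphenyl gives a 1.1-fold higher number from compound 3 to compound 4 (0.05 log units; within the scatter). Read with a 1.7-fold higher number from compound 2 to compound 3 (0.23 log units; within the scatter), this makes two single methoxy removals from this ring, each within the scatter, and the second concerns the aromatic carbon ortho to a methoxy group. No measurement on hand explains this flat result.

Still open, on these data alone, is whether an amine or a carboxylic acid in place of methoxy on this aromatic carbon would move the number beyond the scatter. The compounds shown also leave open what removing the last methoxy would do.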